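A few compounds are considered here, and "the series" means these few. Any claim that something is new, unique, unknown or untested is made for them only; others in the source may bear on it.

Measured compounds:
compound 1, `CCOC(=O)[C@H](CCC(=O)O)NC(=O)c1ccc(CNc2nc3cc(N)cc(N)c3nc2-c2ccccc2)cc1`: < 100000 nM
compound 2, `Nc1cc(N)c2nc(-c3ccccc3)c(NCc3ccc(Cl)c(Cl)c3)nc2c1`: 15800 nM

In a functional assay on HOP-62 cells (Homo sapiens) for inhibition, read by sulforhodamine B assay, with a stated time of 48 h (on this read-out higher numbers stand for weaker inhibition of growth and lower numbers for stronger inhibition of growth), compound 2 gives 15800 nM. For compound 1 the value < 100000 nM is a limit of the assay and not a number. Compound 2 therefore stands on the only number shown, the other value being a limit. Compound 3, `COc1ccc(CNc2nc3cc(N)cc(N)c3nc2-c2ccccc2)cc1`, differs from compound 2 in one place: 4-methoxyphenyl in place of 3,4-dichlorophenyl on a saturated chain carbon bound to a nitrogen on an aromatic ring. For the measured compounds named here, no measured pair shows a change of this kind, so the data give no size for such a step. A modest step is expected, a 1.4-fold higher number from compound 2 to compound 3 (0.14 log units; within the scatter), hardly beyond the scatter. Compound 3 is estimated at 22000 nM, within 6000 nM to 80000 nM.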

Compound 3, concentration for 50% growth inhibition: 17400 nM
Compound 3: the middle estimate sits 1.3-fold (0.10 log units) above what was measured; the measured number falls inside the stated range.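

In this assay, 4-methoxyphenyl in place of 3,4-dichlorophenyl on a saturated chain carbon bound to a nitrogen on an aromatic ring gives a 1.1-fold higher number from compound 2 to compound 3 (0.04 log units; within the scatter). For the compounds shown here, this is the first size seen for a change at this place, and the exchange of both chlorines for a methoxy, with one hydrogen-bond acceptor entering, leaves the two compounds indistinguishable. Nothing at hand accounts for this result. Going by these compounds, the chlorines and the methoxy change together here, so their separate contributions remain unknown. Also open, on these data alone, is whether an amine or a carboxylic acid on this ring, or a longer chain at this place, would move the number beyond the scatter.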